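Working notes: from compound 3 to compound 4

The compounds below may be only part of what the source reports. "The series", "measured", "known", "first", "only" and "open" are said of these compounds alone.

Measured so far in a functional assay on MCF7 cells (Homo sapiens) for antiproliferative activity, read by MTT assay, with a stated time of 72 h (on this read-out higher numbers stand for weaker inhibition and lower numbers for stronger inhibition), in this series:
compound 1 (`COc1cc(-n2cnc3ccc(-c4ccc(C(C)=O)cc4)cc32)cc(OC)c1OC`) gives 1540 nM here
compound 2 (`COc1ccc(-c2ccc3ncn(-c4cc(OC)c(OC)c(OC)c4)c3c2)cc1F`) gives 520 nM here
compound 3 (`COc1cc(-n2cnc3ccc(-c4ccc(C(F)(F)F)cc4)cc32)cc(OC)c1OC`) gives 760 nM here

Compound 3 stands second highest of the three numbers. Its gap to one neighbour stays within the scatter (a 1.5-fold higher number from compound 2 to compound 3 (0.16 log units; within the scatter)), and its gap to the other goes beyond it (a 2.0-fold lower number from compound 1 to compound 3 (0.31 log units; beyond the scatter)).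

The next compound, compound 4 (`COc1cc(-n2cnc3ccc(-c4cccc(Cl)c4)cc32)cc(OC)c1OC`), carries 3-chlorophenyl in place of 4-(trifluoromethyl)phenyl on an aromatic carbon. Among the compounds with values here, all three measured steps are changes at this same place on the shared core, and none of them brings in 3-chlorophenyl, so no direct precedent exists. The largest of them is still modest (a 3.0-fold lower number from compound 1 to compound 2 (0.47 log units; beyond the scatter)), which suggests that no large shift should be expected in this assay for this change. No direction is favoured, and no step beyond the scatter is expected. The expected step (a 1.1-fold lower number from compound 3 to compound 4 (0.04 log units; within the scatter)) is therefore small. Compound 4 is estimated at 700 nM with an expected range of 300 nM to 1600 nM in this read-out.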

Compound 4, half-maximal inhibitory concentration: 3120 nM
Compound 4: the middle estimate sits 4.5-fold (0.65 log units) below what was measured; measured number above the stated range.
By their numbers in this assay, from the lowest: compounds 2 and 3 (each within the scatter of the next); then compound 1; then compound 4.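

In this assay, within the data shown here, the group at this place on the shared core can move the number further than the earlier compounds showed: a 6.0-fold higher number from compound 2 to compound 4 (0.78 log units; beyond the scatter) is the widest step, and a 4.1-fold higher number from compound 3 to compound 4 (0.61 log units; beyond the scatter) also exceeds every earlier step. The former top of the range is passed as well, with a 2.0-fold higher number from compound 1 to compound 4 (0.31 log units; beyond the scatter), which leaves compound 4, with 3-chlorophenyl, as the weakest of the four. No measurement at hand accounts for this rise.

Still open, going by these compounds, is whether the rise follows the chlorine itself or its place on the phenyl ring, a question that 4-chlorophenyl and unsubstituted phenyl at this position would help to separate. On these data alone, how a phenyl ring bearing an amine or a carboxylic acid would read here is also open.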